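A few compounds are considered here, and "the series" means these few. Any claim that something is new, unique, unknown or untested is made for them only; others in the source may bear on it.

Compounds measured so far, with their numbers in an assay on 1321N1 cells for antagonist activity at P2Y purinoceptor 6 (Mus musculus), read by FLIPR and calcium flux; a higher number here means a weaker inhibitor, a lower number a stronger inhibitor:

compound 1 `O=[N+]([O-])C1=Cc2cccc(Cl)c2OC1C(F)(F)F` — 15200 nM
compound 2 `O=[N+]([O-])C1=Cc2cc(F)cc(F)c2OC1C(F)(F)F` — 17800 nM
compound 3 `O=[N+]([O-])C1=Cc2cc(I)ccc2OC1C(F)(F)F` — 28700 nM

All three share the same core and all three are weak inhibitors in this assay. Compound 2 sits between compound 1 and compound 3 on these numbers, but the gaps in either direction are small: the number for compound 1 and the number for compound 3 both lie within the usual scatter of the number for compound 2, so none of the three can be called stronger or weaker than another.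

Compound 4 `O=[N+]([O-])C1=Cc2cc(F)cc(Br)c2OC1C(F)(F)F` is not yet measured in this assay. It differs from compound 2 in one place: bromo in place of fluoro on an aromatic carbon. Within the data shown here, no measured pair shows a step of exactly this kind, so the size of the step can only be guessed from the spread of the three numbers, which is narrow. Compound 1 carries chloro at a similar position and gives 15200 nM, which argues for a number near the others. Compound 4 is therefore expected to give 12000 nM in this assay, with a plausible range from 5000 nM to 30000 nM. The expected step from compound 2 to compound 4 is a 1.5-fold lower number from compound 2 to compound 4 (0.17 log units; within the scatter), and it may well fall within the scatter.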

Compound 4, half-maximal inhibitory concentration: 14500 nM
Compound 4: middle estimate off by 1.2-fold (0.08 log units), on the low side, within the range that was stated.
By their numbers in this assay, from the lowest: compounds 4, 1, 2 and 3 (each within the scatter of the next).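

Among these compounds, this is the first pair of measured compounds that differ in only one place. In this assay, bromo in place of fluoro on an aromatic carbon, ortho to a fused ring, gives a 1.2-fold lower number from compound 2 to compound 4 (0.09 log units; within the scatter), so at this position the assay does not separate these two halogens. Nothing measured here offers an explanation for this result.

From the compounds shown here alone, compound 2 and compound 4 both carry a single halogen atom at this position, so it remains open whether an amine, a carboxylic acid or a methoxy group there would move the number beyond the scatter. Also open, going by these compounds, is whether the same exchange would give a similar result at the other fluoro group, which stays in place in both compounds.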